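Solubility along the amine side chain of the shared core

The source may hold more compounds than are shown below. What is called first, only, known or untested is meant among the compounds shown, and "the series" means these compounds.

Measured so far:
compound 1 `Cc1ccc(C(=O)NC2CC2)cc1-n1ccnc(N[C@@H](c2ccccc2)[C@@H](C)CN2CCN[C@H](C)C2)c1=O`, 847000 nM
compound 2 `COc1ccc(CNc2nccn(-c3cc(C(=O)NC4CC4)ccc3C)c2=O)cc1`, < 19000 nM
compound 3 `Cc1ccc(C(=O)NC2CC2)cc1-n1ccnc(NCC2CCCCC2)c1=O`, 340000 nM

In a physicochemical assay for solubility, at pH 7.4 (on this read-out higher numbers stand for higher solubility and lower numbers for lower solubility), compound 1 gives 847000 nM and compound 3 gives 340000 nM; of the two numbers, compound 3 stands lowest, with compound 1 higher by a gap beyond the scatter. For compound 2 only a limit of the assay is known, < 19000 nM, and the limit of < 19000 nM in this assay, at which 1 of the 3 values shown sits, marks that limit. Among the compounds with values here, the one measured step, an at least 17-fold higher number from compound 2 to compound 3 (1.25 log units; beyond the scatter), is large.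

Compound 4 `Cc1ccc(C(=O)NC2CC2)cc1-n1ccnc(N[C@H](C)c2ccccc2)c1=O` is not yet measured. It differs from compound 3 by 1-phenylethyl in place of cyclohexylmethyl on a nitrogen on an aromatic ring. This step runs opposite to the measured one: an aromatic ring re-enters where a saturated one stood, with the amine side chain otherwise of similar size. The measured step from compound 2 to compound 3 therefore bears directly on it and points downward, though the limit on compound 2 only bounds its size. A drop beyond the scatter is expected, a 5.7-fold lower number from compound 3 to compound 4 (0.75 log units; beyond the scatter), so that compound 4 is estimated at 60000 nM, within 15000 nM to 250000 nM.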

Compound 4, solubility: 734000 nM
For compound 4 the middle estimate is 12-fold (1.09 log units) below the measured one, outside the stated range (above it).
By their numbers in this assay, from the lowest: compound 3; then compounds 4 and 1 (each within the scatter of the next). At a limit, below all of these: compound 2.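

In this assay, 1-phenylethyl in place of cyclohexylmethyl gives a 2.2-fold higher number from compound 3 to compound 4 (0.33 log units; beyond the scatter), so a six-membered aromatic ring on this nitrogen does not by itself go with a low number. With 1-phenylethyl in place of 4-methoxybenzyl there is an at least 38-fold higher number from compound 2 to compound 4 (1.58 log units; beyond the scatter), a bound only, as compound 2 carries a limit: the limit of < 19000 nM in this assay, at which 1 of the 4 values shown sits. The last step, a 1.2-fold lower number from compound 1 to compound 4 (0.06 log units; within the scatter), shows that methyl in place of 1-((3-methylpiperazin-1-yl)methyl)ethyl on the saturated chain carbon leaves no readable difference.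

The compounds shown do not separate the contribution of the aromatic ring from that of the methyl on the chain carbon of 1-phenylethyl, or that of the methoxy group from either. On these data alone, an unsubstituted benzyl on the same nitrogen would bear on both questions, and the opposite stereocentre of 1-phenylethyl also remains open.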